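This account rests on a few compounds, and the source may have more. Where it says the series, first, only, none or still open, it means among the compounds named here.

In a functional assay on HCT-116 cells (Homo sapiens) for antiproliferative activity, read by MTT assay, with a stated time of 72 h (a higher number here means a weaker inhibitor, a lower number a stronger inhibitor), compound 2 `CC(C)C[C@H](NC(=O)OCc1ccccc1)C(=O)N[C@@H](CC(C)C)C(=O)N[C@@H](CC(C)C)C(=O)C(=O)Nc1cccc2ccccc12` stands at a limit, < 100 nM, and not at a number. Compound 1 `CC(C)C[C@H](NC(=O)OCc1ccccc1)C(=O)N[C@@H](CC(C)C)C(=O)N[C@@H](CC(C)C)C(=O)C(=O)NCc1ccc(F)cc1` gives 930 nM in this assay. Compound 3 `CC(C)CNC(=O)C(=O)[C@H](CC(C)C)NC(=O)[C@H](CC(C)C)NC(=O)[C@H](CC(C)C)NC(=O)OCc1ccccc1` carries isobutyl in place of naphthalen-1-yl on an amide-type nitrogen. Within the data shown here, the one measured step bearing on this change is an at least 9.3-fold lower number from compound 1 to compound 2 (0.96 log units; beyond the scatter), with naphthalen-1-yl taking the place of 4-fluorobenzyl on an amide-type nitrogen. Removing naphthalen-1-yl is therefore expected to give a step of similar size in the opposite direction, towards a higher number in this assay. The estimated step is an at least 6.0-fold higher number from compound 2 to compound 3 (0.77 log units; beyond the scatter). For compound 3 the expected value is 600 nM, within an estimated range of 150 nM to 2000 nM.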

Compound 3, half-maximal inhibitory concentration: 810 nM
Compound 3: middle estimate off by 1.4-fold (0.13 log units), on the low side, and the stated range covers the measured number.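

In this assay, naphthalen-1-yl on the amide-type nitrogen now stands apart from a second replacement, with an at least 8.1-fold higher number from compound 2 to compound 3 (0.90 log units; beyond the scatter). Isobutyl, which has no ring, and 4-fluorobenzyl cannot be told apart at this position, with a 1.1-fold lower number from compound 1 to compound 3 (0.06 log units; within the scatter). From the compounds shown here alone, compound 2 stands at a limit and not at a number, so the full size of its step remains unknown: the limit of < 100 nM in this assay, at which 1 of the 3 values shown sits. Going by these compounds, whether a phenyl group, a naphthalen-2-yl group or a longer chain on this nitrogen would side with compound 2 or with compound 1 and compound 3 stays open.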